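The source may report more compounds than this note shows. Statements on the series, on what has been measured and on what is new or still open speak of the compounds shown alone.

Compound 2 `Cc1ccc(C(=O)N2N=C(c3ccc(N4CCN(C)CC4)cc3)CC2c2ccc(N(C)C)cc2)cc1` stands lowest of the two measured numbers in a functional assay on HCC1806 cells (Homo sapiens) for inhibition, read by sulforhodamine B assay, tested at 10 uM (a lower number here means less inhibition, a higher number more inhibition at the concentration tested (going by the name of the read-out)), where compound 2 gives -2.5%, while compound 1 `CN1CCN(c2ccc(C3=NNC(c4ccc(N(C)C)cc4)C3)cc2)CC1` gives 31.2%. Among the compounds with values here, the one measured step, a number 33.7 percentage points lower from compound 1 to compound 2 (beyond the scatter), added the (4-methylphenyl)carbonyl on the amine nitrogen in the ring. Compound 3 `CN1CCN(c2ccc(C3=NN(C(=O)/C=C/c4ccccc4)C(c4ccc(N(C)C)cc4)C3)cc2)CC1` keeps that carbonyl and alters only the group on it: 2-phenylethenyl in place of 4-methylphenyl on a carbonyl carbon. Within the data shown here, no measured step touches this position, so no direction beyond the scatter is expected. Compound 3 is estimated at 0%, between -15% and 15%, which means an expected step of a number 2.5 percentage points higher from compound 2 to compound 3 (within the scatter) within the scatter.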

Compound 3, a percentage reported as inhibition, at one concentration (the size of the read-out at that concentration, not a potency): 71%
Estimate against measurement, compound 3: 71 percentage points below; measured number outside the range, above it.
By their numbers in this assay, from the lowest: compound 2; then compound 1; then compound 3.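

At this position the group on the carbonyl carbon sets the outcome: 2-phenylethenyl in place of 4-methylphenyl gives a number 73.5 percentage points higher from compound 2 to compound 3 (beyond the scatter). Filling the ring nitrogen with a carbonyl group therefore does not lower the number in itself, since (2-phenylethenyl)carbonyl in place of hydrogen gives a number 39.8 percentage points higher from compound 1 to compound 3 (beyond the scatter), opposite in direction to the step with (4-methylphenyl)carbonyl. No measurement at hand explains this gap.

Open, on these data alone, is whether the double bond is needed, which 2-phenylethyl on the same carbonyl carbon would address. Also open, as far as these compounds go, is whether the phenyl ring of that group can carry an amine or a carboxylic acid.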